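The compounds below may be only part of what the source reports. "The series", "measured", "known", "first", "only" and "open" are said of these compounds alone.

All three measured compounds were tested in an in vitro assay on HEK385-7 cells for displacement of a labelled ligand from prostaglandin D2 receptor 2 (Homo sapiens); a lower number here means a stronger inhibitor, a higher number a weaker inhibitor:

Compound 1, `O=C(O)Cc1sc(C(c2ccccc2)c2ccccc2)nc1-c1ccccc1`, gives 570 nM.
Compound 2, `O=C(O)Cc1sc(C(c2ccc(F)cc2)c2ccc(F)cc2)nc1-c1ccccc1`, gives 16 nM.
Compound 3, `O=C(O)Cc1sc(C(c2ccccc2)c2ccccc2)nc1-c1ccc(F)cc1`, gives 8.7 nM.

Compound 1 and compound 3 share a core and differ in one place: fluoro in place of hydrogen on an aromatic carbon. That single change produced a 66-fold lower number from compound 1 to compound 3 (1.82 log units; beyond the scatter). Compound 2 is built on a different core from compound 1; the difference between the two cores is not broken down here. In this assay compound 2 lies close to compound 3 and far from compound 1.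

Compound 4, `O=C(O)Cc1sc(C(c2ccc(F)cc2)c2ccc(F)cc2)nc1-c1cccc(F)c1`, has not yet been measured in this assay. It differs from compound 2 in one place: fluoro in place of hydrogen on an aromatic carbon. For the measured compounds named here, this is the same kind of change as the one from compound 1 to compound 3, but not the same: in compound 3 the fluoro sits para to a large group, while in compound 4 it sits meta to a large group.

The earlier step of a 66-fold lower number from compound 1 to compound 3 (1.82 log units; beyond the scatter) was large, yet compound 2 already gives 16 nM, and the place of the new fluoro is not identical, so a smaller step is expected here. Compound 4 is expected to give 5 nM, most likely between 1.5 nM and 20 nM. This estimate corresponds to an expected step of a 3.2-fold lower number from compound 2 to compound 4 (0.51 log units; beyond the scatter).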

Compound 4, half-maximal inhibitory concentration: 1.4 nM
For compound 4 the middle estimate is 3.6-fold (0.55 log units) above the measured one; measured number outside the range, below it.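

In this assay, fluoro in place of hydrogen on an aromatic carbon gave an 11-fold lower number from compound 2 to compound 4 (1.06 log units; beyond the scatter), so on the core of compound 2 this change again produced a stronger inhibitor, as it did on the core of compound 1. The direction carried over from one core to the other, but the size of the step did not: the same change on two cores in this assay, a 66-fold lower number (1.82 log units; beyond the scatter) from compound 1 to compound 3 and an 11-fold lower number (1.06 log units; beyond the scatter) from compound 2 to compound 4, 5.7-fold (0.76 log units) apart, beyond the scatter of two such steps

The two pairs differ both in the core and in where the fluoro sits, since in compound 4 it is meta to a large group and in compound 3 it is in a different place, so two pairs cannot tell which of these differences sets the size of the step, and they give no rule for further cores.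

The compounds shown leave open whether the 3-fluorophenyl group would give a similar step on the core of compound 1, which would separate the effect of the core from that of the fluoro's place. They also leave open how other groups in that same place, such as chloro, methoxy or an amine, would compare with fluoro.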